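The compounds below may be only part of what the source reports. "The series", "measured", "known", "first", "only" and "open" are said of these compounds alone.

Compound 1 `Cc1cc(C)c(C(=O)N2CCCn3nc(C(=O)Nc4ccccc4)cc3C2)o1`: 2600 nM
Compound 2 `Cc1ccoc1C(=O)N1CCCn2nc(C(=O)NCc3ccccc3)cc2C1`: 50000 nM

In an ADME assay on BEAS-2B cells (Homo sapiens) for cytotoxicity, read by fluorescence, with a stated time of 48 h (a lower number here means that less compound is tolerated, a higher number that more compound is tolerated), compound 2 stands highest of the two at 50000 nM, so more of it is tolerated, while compound 1 gives a clearly lower number at 2600 nM. The gap between these two compounds lies beyond the usual scatter.

Compound 3 `Cc1ccccc1NC(=O)c1cc2n(n1)CCCN(C(=O)c1occc1C)C2` has the same atoms as compound 2, joined differently: 2-methylphenyl in place of benzyl on an amide-type nitrogen. The change is 2-methylphenyl in place of benzyl on an amide-type nitrogen. For the measured compounds named here, no measured pair shows this change alone, so any forecast is loose. Going by the values given here, the only other guide is compound 1 at 2600 nM, which also differs from compound 2 elsewhere in the structure.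

A moderate fall beyond the scatter in this assay is expected, shown by the estimated step of a 4.2-fold lower number from compound 2 to compound 3 (0.62 log units; beyond the scatter). Compound 3 is expected at about 12000 nM, with an estimated range of 2500 nM to 50000 nM.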

Compound 3, half-maximal cytotoxic concentration: 1100 nM
Compound 3: middle estimate off by 11-fold (1.04 log units), on the high side; measured number outside the range, below it.
By their numbers in this assay, from the lowest: compound 3; then compound 1; then compound 2.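

Putting 2-methylphenyl in place of benzyl on the amide-type nitrogen gives a 45-fold lower number from compound 2 to compound 3 (1.66 log units; beyond the scatter) in this assay and shows that this position is highly sensitive to the group it carries. The two groups look alike by simple counts: each has the same number of heavy atoms, one six-membered aromatic ring of carbon only, and no hydrogen-bond donors or acceptors. Those counts therefore do not separate compound 2 from compound 3, and nothing available accounts for the size of the step.

It remains open whether the whole 2-methylphenyl group or only part of it sets this result, as no pair shown changes just one part. From the compounds shown here alone, how a longer chain such as 2-phenylethyl, or a benzyl group bearing an amine, would fare on the same nitrogen is also open.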